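Replacing a hydroxy with hydrogen in compound 1

The source may report more compounds than this note shows. Statements on the series, on what has been measured and on what is new or still open speak of the compounds shown alone.

compound 1 `CC[C@H](C)[C@H]1C(=O)N[C@H](Cc2ccc(O)c(Br)c2)C(=O)N[C@@H](C(C)(C)O)C(=O)O[C@H](c2ccccc2)[C@H](C)/C=C/C=C(\C)[C@H](OC)C/C=C(\C)C(=O)N1C` gives 11.4 nM
compound 2 `CC[C@H](C)[C@H]1C(=O)N[C@H](Cc2ccc(O)c(Br)c2)C(=O)N[C@@H](C(C)(C)O)C(=O)O[C@H](c2ccccc2)[C@H](C)/C=C/C=C(\C)[C@H](OC)C[C@@H]2O[C@@]2(C)C(=O)N1C` gives 9.61 nM
compound 3 `CC[C@H](C)[C@H]1C(=O)N[C@H](Cc2cc(Cl)c(O)c(Cl)c2)C(=O)N[C@@H](C(C)(C)O)C(=O)O[C@H](c2ccccc2)[C@H](C)/C=C/C=C(\C)[C@H](OC)C/C=C(\C)C(=O)N1C` gives 11.3 nM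

In a functional assay on PANC-1 cells (Homo sapiens) for antiproliferative activity (on this read-out higher numbers stand for weaker inhibition and lower numbers for stronger inhibition), compound 1 stands level with compound 2 and compound 3, since all three values lie within the usual scatter of one another. Compound 4 `CC[C@H](C)[C@H]1C(=O)N[C@H](Cc2ccc(O)c(Br)c2)C(=O)N[C@@H](C(C)C)C(=O)O[C@H](c2ccccc2)[C@H](C)/C=C/C=C(\C)[C@H](OC)C/C=C(\C)C(=O)N1C` has not yet been measured. Its difference from compound 1 is hydrogen in place of hydroxy on a saturated chain carbon bound to two saturated chain carbons and a saturated ring carbon and in words it is hydrogen in place of hydroxy on a saturated chain carbon bound to two saturated chain carbons and a saturated ring carbon, so 1-hydroxy-1-methylethyl becomes isopropyl. Within the data shown here, no measured pair tests this change directly. Among the measured compounds shown here, the one measured step is a 1.0-fold lower number from compound 1 to compound 3 (0.00 log units; within the scatter) and it puts 3,5-dichloro-4-hydroxyphenyl in place of 3-bromo-4-hydroxyphenyl, a change at a different place that stays within the scatter. It offers only weak guidance here, so no step beyond the scatter is expected, though the range must stay wide. The expected step is a 1.3-fold higher number from compound 1 to compound 4 (0.12 log units; within the scatter) as an estimate. For compound 4 the estimated value is 15 nM with an expected range from 5 nM to 50 nM as the likely span.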

Compound 4, half-maximal inhibitory concentration: 55.8 nM
Compound 4: the middle estimate sits 3.7-fold (0.57 log units) below what was measured; measured number outside the range, above it.
By their numbers in this assay, from the lowest: compounds 2, 3 and 1 (each within the scatter of the next); then compound 4.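

Unlike the change in the aromatic group, where a 1.0-fold lower number from compound 1 to compound 3 (0.00 log units; within the scatter) stays within the scatter, the change from 1-hydroxy-1-methylethyl to isopropyl moves the number beyond the scatter in this assay, with a 4.9-fold higher number from compound 1 to compound 4 (0.69 log units; beyond the scatter). This shows that the hydroxy at this position counts for the inhibition seen on these cells, although a step of this size is modest and compound 4 still gives 55.8 nM. Nothing in the available data explains why removing this one hydroxy weakens inhibition.

The compounds shown compare only hydroxy and hydrogen here, so it remains open whether a methoxy, an amine or a fluorine at this carbon would keep the number near that of compound 1. On these data alone, it is also open whether the same swap would give a similar step in compound 2 or compound 3.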